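Swapping the aminophenyl on the core of compound 1

The source may report more compounds than this note shows. Statements on the series, on what has been measured and on what is new or still open speak of the compounds shown alone.

Compound 1 `COc1cc(C(=O)c2cn(-c3ccccc3)cc2-c2ccc(N)cc2)cc(OC)c1OC` carries a 4-aminophenyl on its core. In a functional assay on MCF7 cells (Homo sapiens) for cytotoxicity, read by MTT assay, with a stated time of 96 h (on this read-out higher numbers stand for weaker inhibition and lower numbers for stronger inhibition), compound 1 gives 9 nM, the lowest number of the three compounds measured. Compound 3 `COc1ccc(-n2cc(C(=O)c3cc(OC)c(OC)c(OC)c3)c(-c3ccccc3)c2)cc1` gives 120 nM, and compound 2 `COc1cc(C(=O)c2cn(-c3ccccc3C)cc2-c2ccccc2)cc(OC)c1OC` gives 2200 nM. Among the measured compounds shown here, the one measured step, an 18-fold lower number from compound 2 to compound 3 (1.26 log units; beyond the scatter), concerns the group on the aromatic nitrogen and so does not touch the place changed here.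

Compound 4 `COc1cccc(-c2cn(-c3ccccc3)cc2C(=O)c2cc(OC)c(OC)c(OC)c2)c1` differs from compound 1 by 3-methoxyphenyl in place of 4-aminophenyl on an aromatic carbon. For the measured compounds named here, no measured step changes the group on that aromatic carbon, so the data give no direct guide to the size of the step. Going by the values given here, the only comparison that comes near is compound 3, which also carries a methoxy-bearing ring and a plain phenyl and gives 120 nM, well above the number for compound 1. The step from compound 1 to compound 4 is therefore expected to raise the number, an 11-fold higher number from compound 1 to compound 4 (1.05 log units; beyond the scatter). Compound 4 is estimated at 100 nM, within a range from 20 nM to 600 nM.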

Compound 4, half-maximal inhibitory concentration: 180 nM
Compound 4: the middle estimate sits 1.8-fold (0.26 log units) below what was measured, within the range that was stated.
By their numbers in this assay, from the lowest: compound 1; then compounds 3 and 4 (each within the scatter of the next); then compound 2.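

In this assay, among the compounds shown here, the exchange at this aromatic carbon gives a 20-fold higher number from compound 1 to compound 4 (1.30 log units; beyond the scatter) and is beyond the scatter, so this position of the five-membered ring is sensitive to the group it carries, which the earlier compounds, differing only on the aromatic nitrogen, could not show. The change is not a single one, since the 4-aminophenyl counts a hydrogen-bond donor that the 3-methoxyphenyl lacks and the substituent also stands at a different place on the ring. No measurement at hand gives a reason for the size of this step.

The compounds shown leave open whether a 3-aminophenyl or a 4-methoxyphenyl on this carbon would read closer to compound 1 or to compound 4. They therefore cannot separate the effect of the amine from that of its place on the ring.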